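A methyl on the ring of compound 3

This account rests on a few compounds, and the source may have more. Where it says the series, first, only, none or still open, it means among the compounds named here.

Three compounds share a core and differ only in the five-membered aromatic ring attached to it. Compound 1 `c1c[nH]c(-c2ccccc2OCC2=NCCN2)c1` gives 6.31 nM in a functional assay for activation of Alpha-1D adrenergic receptor (Homo sapiens), read by calcium flux; a lower number here means that less compound is needed, a higher number that more compound is needed for the effect. Compound 2 `c1ccc(-c2ccsc2)c(OCC2=NCCN2)c1` gives 12.6 nM in this assay, and compound 3 `c1ccc(-c2ccns2)c(OCC2=NCCN2)c1` gives 25.1 nM. For the measured compounds named here, compound 3 thus has the highest number of the three: the step of a 2.0-fold higher number from compound 2 to compound 3 (0.30 log units; within the scatter) is within the scatter, the step of a 2.0-fold higher number from compound 1 to compound 2 (0.30 log units; within the scatter) is within it as well, and only the step of a 4.0-fold higher number from compound 1 to compound 3 (0.60 log units; beyond the scatter) lies beyond it.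

Compound 4 `Cc1cc(-c2ccccc2OCC2=NCCN2)sn1` follows from compound 3 by the change (methyl in place of hydrogen on an aromatic carbon). Going by the values given here, none of the measured steps bears on this directly: each of them exchanges one five-membered ring for another, and none adds a methyl to a ring that is otherwise kept. Even those ring exchanges moved the number by modest amounts at most. Among the compounds with values here, with no measured step of the same kind, a small shift in either direction, or none beyond the scatter, is expected in this assay. Compound 4 is therefore expected to give 30 nM, with a range from 10 nM to 90 nM. The expected step of a 1.2-fold higher number from compound 3 to compound 4 (0.08 log units; within the scatter) stays close to the scatter of the measurement.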

Compound 4, half-maximal effective concentration: < 100000 nM
Compound 4: a limit, no number; the forecaster's own chance of this, stated with the estimate: 2%; the middle value lies beyond the limit too.
By their numbers in this assay, from the lowest: compounds 1, 2 and 3 (each within the scatter of the next, the first and the last beyond it).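

In this assay compound 4 gives < 100000 nM, which is a limit and not a number, and none of its steps from compound 1, compound 2 or compound 3 can be read. On these data alone, whether the methyl on compound 4 moves the number in this assay at all, and in which direction, stays open.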